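The source may report more compounds than this note shows. Statements on the series, on what has been measured and on what is new or still open speak of the compounds shown alone.

Working notes on the series. Two compounds have been run in a functional assay on HCT-15 cells (Homo sapiens) for antiproliferative activity, read by sulforhodamine B assay; on this read-out higher numbers stand for weaker inhibition of growth and lower numbers for stronger inhibition of growth. Compound 1 `CC1CC(=O)c2s/c(=N/c3ccccc3)oc2C1` gives 2070 nM in this assay. Compound 2 `CC1(C)CC(=O)c2s/c(=N/c3ccc(Cl)cc3)oc2C1` gives 3790 nM, the higher of the two numbers on record, though its gap to compound 1 lies within the scatter; the two compounds differ in more than one place, so nothing is drawn from that pair beyond the two values themselves.

Compound 3 `CC1CC(=O)c2s/c(=N/c3ccc(Cl)cc3)oc2C1` has not yet been measured in this assay. Against compound 2 it differs by hydrogen in place of methyl on a saturated ring carbon. Within the data shown here, no single-change step between measured compounds is available to calibrate this change. Given that the only numbers so far sit close together, the expected step is a 1.3-fold lower number from compound 2 to compound 3 (0.10 log units; within the scatter), meaning none beyond the scatter. Compound 3 is accordingly estimated at 3000 nM in this assay, with a range from 1200 nM to 7500 nM.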

Compound 3, concentration for 50% growth inhibition: 12200 nM
Compound 3: middle estimate off by 4.1-fold (0.61 log units), on the low side; the whole stated range lies below it.
By their numbers in this assay, from the lowest: compounds 1 and 2 (each within the scatter of the next); then compound 3.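

In this assay, the saturated ring carbon is now shown to respond to a single change: with chloro on the aromatic carbon, hydrogen in place of methyl gives a 3.2-fold higher number from compound 2 to compound 3 (0.51 log units; beyond the scatter), a step beyond the scatter towards weaker inhibition of growth. The aromatic carbon responds as well: with one methyl on the saturated ring carbon, chloro in place of hydrogen gives a 5.9-fold higher number from compound 1 to compound 3 (0.77 log units; beyond the scatter), also beyond the scatter and towards weaker inhibition of growth. No measurement at hand accounts for either step.

Going by these compounds, whether the methyl step holds with hydrogen instead of chloro on the aromatic carbon remains open. Also open, on these data alone, is how an ethyl group on the saturated ring carbon, or a fluoro or methoxy group in place of chloro on the aromatic carbon, would read.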